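Swapping the phenylethenyl chain for phenyl on the core

The source may hold more compounds than are shown below. What is called first, only, known or untested is meant among the compounds shown, and "the series" means these compounds.

Measured compounds:
compound 1 `COc1ccc(C(O)(Cc2ccc(F)cc2)c2cccc3ccccc23)c(OC)c1OC`, 5440 nM
compound 2 `COc1ccc(C(O)(C/C=C\c2ccccc2)c2cccc3ccccc23)c(OC)c1OC`, 12800 nM
compound 3 `COc1ccc(C(OCc2ccccc2)c2cccc3ccccc23)c(OC)c1OC`, > 20000 nM

In a functional assay on MDA-MB-231 cells (Homo sapiens) for inhibition, read by sulforhodamine B assay, with a stated time of 48 h (on this read-out higher numbers stand for weaker inhibition and lower numbers for stronger inhibition), compound 2 gives the highest of the two numbers shown; the nearest is compound 1, whose value is lower by a 2.4-fold higher number from compound 1 to compound 2 (0.37 log units; beyond the scatter). For compound 3 the assay reports only a limit, (the limit of > 20000 nM in this assay, at which 1 of the 3 values shown sits).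

Compound 4 `COc1ccc(C(O)(Cc2ccccc2)c2cccc3ccccc23)c(OC)c1OC` has not yet been measured. It differs from compound 2 by phenyl in place of 2-phenylethenyl on a saturated chain carbon, two bonds along the chain from two aromatic carbons and an oxygen on a saturated carbon. For the measured compounds named here, the one measured step that bears on this change is a 2.4-fold higher number from compound 1 to compound 2 (0.37 log units; beyond the scatter), in which 2-phenylethenyl entered at the same place and the number rose by a modest amount beyond the scatter. Compound 4 moves in the opposite direction, removing 2-phenylethenyl, so a modest lowering of the number is expected, with the unmeasured change from 4-fluorophenyl to phenyl left as an open question.

Compound 4 is therefore expected to give 6000 nM in this assay, within 2500 nM to 15000 nM, which corresponds to an estimated step of a 2.1-fold lower number from compound 2 to compound 4 (0.33 log units; beyond the scatter).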

Compound 4, half-maximal inhibitory concentration: 4780 nM
For compound 4 the middle estimate is 1.3-fold (0.10 log units) above the measured one, and the stated range covers the measured number.
By their numbers in this assay, from the lowest: compounds 4 and 1 (each within the scatter of the next); then compound 2. At a limit, above all of these: compound 3.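

In this assay, phenyl in place of 2-phenylethenyl gives a 2.7-fold lower number from compound 2 to compound 4 (0.43 log units; beyond the scatter), so the earlier rise with 2-phenylethenyl at this saturated chain carbon now also appears against a phenyl group without fluoro. Hydrogen in place of fluoro on an aromatic carbon gives a 1.1-fold lower number from compound 1 to compound 4 (0.06 log units; within the scatter), so the fluoro group makes no difference that this assay can separate, and compound 1 and compound 4 stand together against compound 2. Nothing measured here gives a cause for either step.

The compounds shown leave open whether a saturated 3-phenylpropyl chain at this place would behave like the 2-phenylethenyl group or like phenyl. They also leave open how an amine or a carboxylic acid on the phenyl ring would change the number.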